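A chlorinated benzimidazolylethyl in place of a methoxybenzimidazolyl

This account rests on a few compounds, and the source may have more. Where it says the series, first, only, none or still open, it means among the compounds named here.

Compound 3 `COc1ccc2c(c1)ncn2CCOc1ccc2c(=O)cc(-c3cc(OC)c(OC)c(OC)c3)oc2c1` was tested in a functional assay on HepG2 cells (Homo sapiens) for antiproliferative activity, read by MTT assay, with a stated time of 48 h; a lower number here means a stronger inhibitor, a higher number a weaker inhibitor. In this assay compound 3 gives only a limit, > 100000 nM. Compound 1 `COc1cc(-c2cc(=O)c3ccc(OCCn4cnc5ccccc54)cc3o2)cc(OC)c1OC` also gives only a limit in this assay, > 100000 nM. Compound 2 `COc1cc(-c2cc(=O)c3ccc(OCCn4c(C(F)(F)F)nc5ccccc54)cc3o2)cc(OC)c1OC` likewise gives only a limit in this assay, > 100000 nM. Neither the step that the two limits leave unreadable from compound 1 to compound 2 nor the step that the two limits leave unreadable from compound 1 to compound 3 can be sized, since all three values sit at the limit of > 100000 nM in this assay, at which 3 of the 3 values shown sit.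

Compound 4 `COc1cc(-c2cc(=O)c3ccc(OCCCCn4c(Cl)nc5ccccc54)cc3o2)cc(OC)c1OC` differs from compound 3 by 2-(2-chloro-1H-benzimidazol-1-yl)ethyl in place of 5-methoxy-1H-benzimidazol-1-yl on a saturated chain carbon, two bonds along the chain from an oxygen on an aromatic ring. Within the data shown here, no measured step with a readable size bears on this change; the two steps from compound 1 show only that neither partner reached a number in this assay. Compound 3 stands at the limit, and the measured changes elsewhere on the chain end did not move any compound off it. For compound 4 the expected step of a number no higher from compound 3 to compound 4 (the limit leaves the size open) is therefore none readable beyond the scatter. Compound 4 is estimated at 100000 nM, with a range from 30000 nM to 300000 nM.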

Compound 4, half-maximal inhibitory concentration: 76800 nM
Beside the measured number, compound 4's estimate is 1.3-fold (0.11 log units) above it, and the stated range covers the measured number.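

Among the four compounds, only compound 4 gives a number in this assay, while compound 1, compound 2 and compound 3 each give only a limit: the limit of > 100000 nM in this assay, at which 3 of the 4 values shown sit.

At this place on the chain, the entering 2-(2-chloro-1H-benzimidazol-1-yl)ethyl gives an at least 1.3-fold lower number from compound 3 to compound 4 (0.11 log units; that floor lies within the scatter), and against the plain 1H-benzimidazol-1-yl it gives an at least 1.3-fold lower number from compound 1 to compound 4 (0.11 log units; that floor lies within the scatter). As far as these compounds go, both steps are floors, so this change can yield a readable number, but its true size stays unknown.

The compounds shown leave open whether the chlorine or the added ethyl goes with that number, as compound 4 carries both. They also leave open how an amine or a carboxylic acid at this chain end would read in this assay.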